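Urea-linked thienopyrimidines: fluoro to dichloro swap

A few compounds are considered here, and "the series" means these few. Any claim that something is new, unique, unknown or untested is made for them only; others in the source may bear on it.

Measured so far:
compound 1 `CN(C)CCCNc1nc(-c2ccc(NC(=O)Nc3ccc(Cl)cc3)cc2)nc2c(Cl)c(Cl)sc12`: 230 nM
compound 2 `CN(C)CCNc1nc(-c2ccc(NC(=O)Nc3ccc(F)cc3)cc2)nc2ccsc12`: 390 nM

In a functional assay on NCI-H460 cells (Homo sapiens) for cytotoxicity, read by MTT assay, with a stated time of 72 h (a higher number here means a weaker inhibitor, a lower number a stronger inhibitor), compound 1 gives 230 nM and compound 2 gives 390 nM; the two numbers lie within the usual scatter of each other, so nothing separates them. Compound 3 `CN(C)CCNc1nc(-c2ccc(NC(=O)Nc3ccc(Cl)cc3Cl)cc2)nc2ccsc12` differs from compound 2 by 2,4-dichlorophenyl in place of 4-fluorophenyl on an amide-type nitrogen. For the measured compounds named here, no measured pair shows this change, so its size is unknown. The expectation for compound 3 is a step of a 1.3-fold lower number from compound 2 to compound 3 (0.11 log units; within the scatter) that stays within the scatter. Compound 3 is estimated at 300 nM in this assay, with a range from 120 nM to 800 nM.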

Compound 3, half-maximal inhibitory concentration: 1650 nM
For compound 3 the middle estimate is 5.5-fold (0.74 log units) below the measured one; the whole stated range lies below it.
By their numbers in this assay, from the lowest: compounds 1 and 2 (each within the scatter of the next); then compound 3.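

In this assay the aryl group on the amide-type nitrogen proves to be a sensitive place, with a 4.2-fold higher number from compound 2 to compound 3 (0.63 log units; beyond the scatter) on exchanging 4-fluorophenyl for 2,4-dichlorophenyl. For the compounds shown here, this is the first step read at this position, and it shows that the exchange is not tolerated without loss. Nothing on hand accounts for the step.

Open, going by these compounds, is whether the added chlorine or the loss of fluorine carries the change. Also open, on these data alone, is how an unsubstituted phenyl or a 4-methoxyphenyl group would read at this place.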